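A Carbamate Tail on a Scaffold Without Measurable Activity

The compounds below may be only part of what the source reports. "The series", "measured", "known", "first", "only" and "open" are said of these compounds alone.

Compound 1 `CCCn1c(NC(=O)c2ccccn2)nc2cc(C(N)=O)cc(OC)c21` was tested in an assay for activation of interferon regulatory factor 3 (Homo sapiens), read by a luciferase reporter, with a stated time of 20 h; a lower number here means that less compound is needed, a higher number that more compound is needed for the effect. In this assay compound 1 gives > 100000 nM, which is a limit of the assay and not a number. Compound 2 `CCCn1c(NC(=O)CCc2ccccc2)nc2cc(C(N)=O)cc(OC)c21` differs from compound 1 by a phenethyl in place of pyridin-2-yl on a carbonyl carbon. In this assay compound 2 gives > 100000 nM, again a limit rather than a number. The step that the two limits leave unreadable from compound 1 to compound 2 therefore cannot be read, since (the limit of > 100000 nM in this assay, at which 2 of the 2 values shown sit). Compound 3 `COc1cc(C(N)=O)cc2nc(NC(=O)c3ccccn3)n(CCCNC(=O)OCc3ccccc3)c12` has not been measured; it differs from compound 1 by (benzyloxycarbonyl)amino in place of hydrogen on a saturated chain carbon, three bonds along the chain from an aromatic nitrogen. For the measured compounds named here, no measured step touches this part of the molecule, so nothing among the measured compounds speaks for or against a change in this assay. Compound 1 stands at the limit, so only a gain could ever become visible. The step that the limit leaves unreadable from compound 1 to compound 3 is what this expectation amounts to, with no measured basis for any direction. For compound 3 in this assay the estimate is 150000 nM, expected to lie between 20000 nM and 1000000 nM, and most likely the assay will again report only a limit.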

Compound 3, half-maximal effective concentration: > 100000 nM
Compound 3 ended at the assay's limit (the forecaster's own chance of this, stated with the estimate: 80%); the middle value is on the limit's open side.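

In this assay compound 3 gives > 100000 nM, a limit of the assay and not a number. The step from compound 1 to compound 3 therefore cannot be read, as both compounds stop at the same limit: the limit of > 100000 nM in this assay, at which 3 of the 3 values shown sit.

The compounds shown leave open whether the (benzyloxycarbonyl)amino tail raises or lowers the concentration needed for the effect.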